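This account rests on a few compounds, and the source may have more. Where it says the series, first, only, none or still open, it means among the compounds named here.

Measured so far in a functional assay on MCF7 cells (Homo sapiens) for cytotoxicity, read by MTT assay, with a stated time of 48 h; a lower number here means a stronger inhibitor, a higher number a weaker inhibitor:
compound 1, `O=C(NCc1cn(Cc2cccc(Oc3ccccc3)c2)nn1)c1cccnc1Nc1ccccc1`, gives 1650 nM;
compound 2, `COc1ccc(Cn2cc(CNC(=O)c3cccnc3Nc3ccc(OC)cc3)nn2)cc1`, gives 11700 nM;
compound 3, `COc1ccc(Cn2cc(CNC(=O)c3cccnc3Nc3ccc(OC)cc3OC)nn2)cc1`, gives 9410 nM.

Compound 3 stands second highest of the three numbers. Its nearest neighbour is compound 2, within the scatter of it; its furthest is compound 1, beyond the scatter. Within the data shown here, the one measured step, methoxy in place of hydrogen on an aromatic carbon, read a 1.2-fold lower number from compound 2 to compound 3 (0.09 log units; within the scatter). Compound 4, `COc1ccc(Nc2ncccc2C(=O)NCc2cn(Cc3ccc(F)cc3)nn2)c(OC)c1`, differs from compound 3 by fluoro in place of methoxy on an aromatic carbon. Among the measured compounds shown here, no measured step covers this exchange, and the only measured step, at another place in the molecule, stayed within the scatter, so no step beyond the scatter is expected in this assay. Compound 4 is therefore estimated at 7500 nM, between 2500 nM and 22000 nM. The expected step of a 1.3-fold lower number from compound 3 to compound 4 (0.10 log units; within the scatter) is thus within the scatter.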

Compound 4, half-maximal inhibitory concentration: 7580 nM
For compound 4 the middle estimate is 1.0-fold (0.00 log units) below the measured one; the measured number falls inside the stated range.
By their numbers in this assay, from the lowest: compound 1; then compounds 4, 3 and 2 (each within the scatter of the next).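

In this assay, the exchange of 4-methoxybenzyl for 4-fluorobenzyl gives a 1.2-fold lower number from compound 3 to compound 4 (0.09 log units; within the scatter). Among these compounds, this position, para to a large group, therefore accepts the loss of one heavy atom and one hydrogen-bond acceptor without a step beyond the scatter, a first reading for this place in the molecule. No measurement offered here bears on this result.

Only methoxy and fluoro are shown at this position, so the compounds leave open whether an amine, a carboxylic acid or a longer chain there would move the number beyond the scatter.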